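The source may hold more compounds than are shown below. What is called first, only, known or untested is meant among the compounds shown, and "the series" means these compounds.

Compound 1 `N#C/N=C(/NCCCCc1c[nH]cn1)NCCCc1ccccc1` gives 5.25 in an in vitro functional assay on Sf9 cells for antagonist activity at histamine H2 receptor (Homo sapiens); on this read-out lower numbers stand for lower potency and higher numbers for higher potency (the scale is a negative logarithm). Compound 2 `N#C/N=C(/NCCCCc1c[nH]cn1)NCCCC1CCCCC1` reaches only a limit of this assay, < 5, so its position is known no more closely than that. Within the data shown here, the one measured step, a number at least 0.25 log units lower from compound 1 to compound 2 (that floor lies within the scatter), is the only one bearing on the change at hand; its floor sits at the limit of < 5 in this assay, at which 1 of the 2 values shown sits. Compound 3 `N#C/N=C(/NCCCCc1c[nH]cn1)NCCCc1ccc(F)cc1` carries the change (4-fluorophenyl in place of cyclohexyl on a saturated chain carbon, three bonds along the chain from an amine nitrogen), which brings back an aromatic ring like that of compound 1. Compound 3 is therefore expected to rise to about 5.2, between 4.7 and 5.7. The expected step is a number at least 0.20 log units higher from compound 2 to compound 3 (that floor lies within the scatter).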

Compound 3, negative logarithm of the antagonist equilibrium constant: 5.28
Compound 3: middle estimate off by 0.08 log units, on the low side; the measured number falls inside the stated range.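

Fluoro in place of hydrogen on an aromatic carbon gives a number 0.03 log units higher from compound 1 to compound 3 (within the scatter), so in this assay the phenyl and 4-fluorophenyl ends of this chain cannot be told apart. 4-Fluorophenyl in place of cyclohexyl gives a number at least 0.28 log units higher from compound 2 to compound 3 (that floor lies within the scatter), which places a second aromatic end level with the first. The full size of that step remains unknown, and its floor does not clear the scatter: the limit of < 5 in this assay, at which 1 of the 3 values shown sits.

Going by these compounds, whether chloro or methoxy in place of the fluoro, or a pyridyl ring in place of the 4-fluorophenyl, would move the number remains open.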